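Phenethyl on the alkyne of compound 3

A few compounds are considered here, and "the series" means these few. Any claim that something is new, unique, unknown or untested is made for them only; others in the source may bear on it.

Measured in a functional assay on L1210 cells (Mus musculus) for antiproliferative activity, read by MTT assay, with a stated time of 2 days; a higher number here means a weaker inhibitor, a lower number a stronger inhibitor:
- compound 1 `CCCCCCC#Cc1cn(C/C=C/CN2C(=O)c3ccccc3C2=O)c(=O)[nH]c1=O`: 43000 nM
- compound 2 `CCCCCc1ccc(C#Cc2cn(C/C=C/CN3C(=O)c4ccccc4C3=O)c(=O)[nH]c2=O)cc1`: 39000 nM
- compound 3 `CCCCc1ccc(C#Cc2cn(C/C=C/CN3C(=O)c4ccccc4C3=O)c(=O)[nH]c2=O)cc1`: 42000 nM

The three compounds share a core and differ only in the group on a triple-bonded carbon. Compound 3, at 42000 nM, lies within the scatter of both other compounds, so its place among the three numbers carries no order.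

Compound 4 `O=C1c2ccccc2C(=O)N1C/C=C/Cn1cc(C#CCCc2ccccc2)c(=O)[nH]c1=O` carries phenethyl in place of 4-butylphenyl on a triple-bonded carbon. Among the measured compounds shown here, no measured compound carries phenethyl, so the evidence is indirect. For the measured compounds named here, three measured steps bear on this change. Replacing hexyl with an aryl group gave a 1.1-fold lower number from compound 1 to compound 2 (0.04 log units; within the scatter) and a 1.0-fold lower number from compound 1 to compound 3 (0.01 log units; within the scatter), and shortening the chain on the phenyl ring gave a 1.1-fold higher number from compound 2 to compound 3 (0.03 log units; within the scatter). All three are small and within the scatter, so in this assay no step beyond the scatter is expected here, and no direction is favoured. The expected step is no change at the digits printed from compound 3 to compound 4 (within the scatter). Compound 4 is expected at about 42000 nM, with an estimated range from 20000 nM to 85000 nM.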

Compound 4, half-maximal inhibitory concentration: 44000 nM
Compound 4: the middle estimate sits 1.0-fold (0.02 log units) below what was measured; the measured number falls inside the stated range.
By their numbers in this assay, from the lowest: compounds 2, 3, 1 and 4 (each within the scatter of the next).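

In this assay phenethyl in place of 4-butylphenyl on a triple-bonded carbon gave a 1.0-fold higher number from compound 3 to compound 4 (0.02 log units; within the scatter) and phenethyl in place of 4-pentylphenyl gave a 1.1-fold higher number from compound 2 to compound 4 (0.05 log units; within the scatter) so this group, with saturated chain carbons leading to its ring, stands level with the two aryl groups at this place. Phenyl in place of butyl on a saturated chain carbon, two bonds along the chain from a triple-bonded carbon, gave a 1.0-fold higher number from compound 1 to compound 4 (0.01 log units; within the scatter) and so the end of the chain can carry an aromatic ring or a plain alkyl stretch with no step beyond the scatter. Nothing given here offers an explanation of why all four groups at this place stay within the scatter of one another.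

All four groups are built of carbon and hydrogen alone, so the compounds shown leave open whether an amine, a hydroxyl or a carboxylic acid at the end of the chain would give a step beyond the scatter. They also leave open whether a change elsewhere on the shared core would move the number in this assay at all.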